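The source may report more compounds than this note shows. Statements on the series, on what has been measured and on what is new or still open speak of the compounds shown alone.

In a functional assay on MCF7 cells (Homo sapiens) for cytotoxicity, read by MTT assay, with a stated time of 48 h (a higher number here means a weaker inhibitor, a lower number a stronger inhibitor), compound 2 `COc1cc(-c2nnc3n2NC(c2cccs2)C(C(=O)c2ccccc2)S3)cc(OC)c1OC` gives > 100000 nM, which is a limit of the assay rather than a number. Compound 1 `COc1cc(C(=O)C2Sc3nnc(-c4cc(OC)c(OC)c(OC)c4)n3NC2c2ccco2)cc(OC)c1OC` also reaches only a limit in this assay, giving > 100000 nM. Both values therefore sit at the limit of > 100000 nM in this assay, at which 2 of the 2 values shown sit. Compound 3 `COc1cc(C(=O)C2Sc3nnc(-c4cc(OC)c(OC)c(OC)c4)n3NC2c2cccs2)cc(OC)c1OC` differs from compound 2 by 3,4,5-trimethoxyphenyl in place of phenyl on a carbonyl carbon. Because compound 1 stands at the limit of > 100000 nM in this assay, at which 2 of the 2 values shown sit, while already carrying 3,4,5-trimethoxyphenyl on the carbonyl carbon, the expected step in this assay is a step that the limit leaves unreadable from compound 2 to compound 3, none beyond the scatter. Compound 3 is thus expected to give 150000 nM in this assay, between 50000 nM and 500000 nM, most probably again only as a limit.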

Compound 3, half-maximal inhibitory concentration: 71000 nM
The estimate for compound 3 lay 2.1-fold (0.32 log units) above the measured number, within the range that was stated.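

Among the compounds shown here, compound 3 is the only compound here that gives a number rather than a limit in this assay. With an at least 1.4-fold lower number from compound 2 to compound 3 (0.14 log units; that floor lies within the scatter) for 3,4,5-trimethoxyphenyl in place of phenyl on a carbonyl carbon, and an at least 1.4-fold lower number from compound 1 to compound 3 (0.14 log units; that floor lies within the scatter) for thiophen-2-yl in place of furan-2-yl on a saturated ring carbon, neither change can yet be shown to exceed the scatter. The full size of each step stays hidden because compound 1 and compound 2 stop at a limit: the limit of > 100000 nM in this assay, at which 2 of the 3 values shown sit. Still open, going by these compounds, is whether an amine or a carboxylic acid in place of 3,4,5-trimethoxyphenyl on the carbonyl carbon would move the number in this assay at all.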